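A few compounds are considered here, and "the series" means these few. Any claim that something is new, unique, unknown or untested is made for them only; others in the source may bear on it.

In an ADME assay on Vero cells (Chlorocebus sabaeus) for cytotoxicity, read by MTT assay, with a stated time of 96 h (a higher number here means that more compound is tolerated, a lower number that less compound is tolerated), three neighbours are measured: compound 1 (`COc1cc(NCc2ccc(C)o2)ccc1-c1cnco1`) gives 45200 nM and compound 2 (`COc1cc(NCc2ccc(C)s2)ccc1-c1cnco1`) gives 24700 nM while compound 3 (`COc1cc(NCc2scnc2C)ccc1-c1cnco1`) gives 73700 nM in the same read-out. Compound 3 sits within the scatter on one side (a 1.6-fold higher number from compound 1 to compound 3 (0.21 log units; within the scatter)) and beyond it on the other (a 3.0-fold higher number from compound 2 to compound 3 (0.47 log units; beyond the scatter)) so it has a clear margin in that second comparison only.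

Compound 4 (`COc1cc(NCc2cncs2)ccc1-c1cnco1`) loses the methyl of 4-methyl-1,3-thiazol-5-yl, leaving 1,3-thiazol-5-yl (hydrogen in place of methyl on an aromatic carbon) with hydrogen in place of methyl on an aromatic carbon. Among the measured compounds shown here, no measured step removes a methyl group, since all three exchange one methyl-bearing ring for another, so they bear on this change only indirectly. They do show the size of movement seen so far at this part of the structure: the remaining step (a 1.8-fold lower number from compound 1 to compound 2 (0.26 log units; within the scatter)) stays within the scatter, and the largest (a 3.0-fold higher number from compound 2 to compound 3 (0.47 log units; beyond the scatter)) is modest. No step beyond the scatter is therefore expected in this assay and the data give no firm direction. The estimated step (a 1.2-fold lower number from compound 3 to compound 4 (0.09 log units; within the scatter)) is accordingly small. For compound 4 the expected value is 60000 nM as an estimate, with an expected range from 26000 nM to 130000 nM on repeat measurement.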

Compound 4, half-maximal cytotoxic concentration: 232000 nM
Compound 4: middle estimate off by 3.9-fold (0.59 log units), on the low side; the measured number lies above the stated range.
By their numbers in this assay, from the lowest: compounds 2, 1 and 3 (each within the scatter of the next, the first and the last beyond it); then compound 4.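

In this assay, among the compounds shown here, the change from 4-methyl-1,3-thiazol-5-yl to 1,3-thiazol-5-yl (a 3.1-fold higher number from compound 3 to compound 4 (0.50 log units; beyond the scatter)) gives the first reading for taking a methyl away rather than exchanging one methyl-bearing ring for another, and it shows that this single carbon, next to the ring nitrogen and next to the ring atom that bears a large group, moves the number beyond the scatter on its own. Compound 4 also separates from the two other rings, (a 9.4-fold higher number from compound 2 to compound 4 (0.97 log units; beyond the scatter)) and (a 5.1-fold higher number from compound 1 to compound 4 (0.71 log units; beyond the scatter)), so it stands highest of the four, with its steps to all three printed as beyond the scatter. No measurement shown here accounts for the step, so its origin stays unexplained.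

For the compounds shown here, only one methyl-to-hydrogen pair is available, so it remains open whether hydrogen in place of methyl on the 5-methylfuran-2-yl or 5-methylthiophen-2-yl ring would move the number in the same direction. Also open, going by these compounds, is how this carbon of the 1,3-thiazol-5-yl ring would read with an ethyl, a methoxy, a chlorine or an amine in place of the hydrogen.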